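Swapping Bromo for Methyl in a Vessel Relaxation Series

A few compounds are considered here, and "the series" means these few. Any claim that something is new, unique, unknown or untested is made for them only; others in the source may bear on it.

The compounds here were tested in a functional assay on thoracic aorta (Rattus norvegicus, strain Wistar), with a stated time of 15 min; on this read-out lower numbers stand for an effect already at smaller amounts and higher numbers for an effect only at larger amounts of compound. Compound 1 `CC(NC(=O)NS(=O)(=O)c1ccc(Cl)cc1)c1cc(Br)ccc1OCc1ccccc1` gives 57500 nM in this assay. Compound 2 `Cc1ccc(OCc2ccccc2)c(C(C)NC(=O)NS(=O)(=O)c2ccc(Cl)cc2)c1` is compound 1 with one change, (methyl in place of bromo on an aromatic carbon), and in this assay compound 2 gives 65300 nM. The step that this change made is a 1.1-fold higher number from compound 1 to compound 2 (0.06 log units; within the scatter), so the two numbers cannot be told apart by this measurement.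

Compound 3 `Cc1ccc(S(=O)(=O)N(C)C(=O)NC(C)c2cc(Br)ccc2OCc2ccccc2)cc1` is built on a different core; the difference between the cores of compound 1 and compound 3 is not broken down here. In this assay compound 3 gives 67100 nM, which sits within the scatter of both compound 1 and compound 2.

Compound 4 `Cc1ccc(S(=O)(=O)N(C)C(=O)NC(C)c2cc(C)ccc2OCc2ccccc2)cc1` has not yet been measured. It differs from compound 3 by methyl in place of bromo on an aromatic carbon. This is the same change that turned compound 1 into compound 2, made at a place that is described in the same words, and among these four compounds it occurs twice in all. Among the compounds with values here, the only guide to its effect is that one earlier step, which was within the scatter. The step from compound 3 to compound 4 is therefore estimated to be small, a 1.1-fold higher number from compound 3 to compound 4 (0.03 log units; within the scatter), because the same change gave a 1.1-fold higher number from compound 1 to compound 2 (0.06 log units; within the scatter). Compound 4 is expected to give about 72000 nM in this assay. For compound 4 the estimate is expected to fall between 36000 nM and 145000 nM.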

Compound 4, half-maximal effective concentration: 181000 nM
Compound 4: middle estimate off by 2.5-fold (0.40 log units), on the low side, outside the stated range (above it).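

In this assay, putting methyl in place of bromo on the core of compound 3 gives a 2.7-fold higher number from compound 3 to compound 4 (0.43 log units; beyond the scatter), a modest step that stands clear of the usual scatter, whereas on the core of compound 1 the same change gives a 1.1-fold higher number from compound 1 to compound 2 (0.06 log units; within the scatter), which does not. Read alone, these steps might suggest that the core decides how much the change matters, but the gap between them is not large enough to support that: the same change on two cores in this assay, a 1.1-fold higher number (0.06 log units; within the scatter) from compound 1 to compound 2 and a 2.7-fold higher number (0.43 log units; beyond the scatter) from compound 3 to compound 4, 2.4-fold (0.38 log units) apart, within the scatter of two such steps. Within the data shown here, this pair of cores therefore does not show that the effect of the change depends on the core, nor does it prove that the effect carries over unchanged, and only the step on the core of compound 3 can be read as a real difference.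

The compounds shown hold only bromo or methyl at this place, para to the benzyloxy group, so it remains open how a nitrile or a methoxy group there would behave on either core. All four compounds also keep the benzyloxy group itself, which leaves open what an amine or a carboxylic acid in its place would do to the read-out and to this change.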